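This account rests on a few compounds, and the source may have more. Where it says the series, first, only, none or still open, it means among the compounds named here.

Measured so far:
- compound 1 `Nc1ccccc1NC(=O)c1ccc(CSC(=S)N2CCN(c3ccc(F)cc3)CC2)cc1`: 17200 nM
- compound 2 `Nc1ccccc1NC(=O)c1ccc(CSC(=S)N2CCc3cc(Cl)ccc32)cc1`: 1890 nM

In a functional assay on MGC-803 cells (Homo sapiens) for antiproliferative activity, read by CCK-8 assay, with a stated time of 72 h (on this read-out higher numbers stand for weaker inhibition and lower numbers for stronger inhibition), compound 2 holds the lower of the two numbers, 1890 nM, and compound 1 gives 17200 nM. The gap between these two numbers lies beyond the scatter. Compound 3 `CCN(Cc1ccncc1)C(=S)SCc1ccc(C(=O)Nc2ccccc2N)cc1` carries ethyl((pyridin-4-yl)methyl)amino in place of 5-chloro-2,3-dihydro-1H-indol-1-yl on a thiocarbonyl carbon. For the measured compounds named here, no measured step covers this change. Going by the values given here, the only guide is compound 1 at 17200 nM, which also lacks 5-chloro-2,3-dihydro-1H-indol-1-yl. Weaker inhibition is expected, with an estimated step of a 2.6-fold higher number from compound 2 to compound 3 (0.42 log units; beyond the scatter), modestly beyond the scatter. For compound 3 the estimated value is 5000 nM, with an expected range of 1500 nM to 18000 nM.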

Compound 3, half-maximal inhibitory concentration: 1370 nM
For compound 3 the middle estimate is 3.6-fold (0.56 log units) above the measured one; measured number outside the range, below it.
By their numbers in this assay, from the lowest: compounds 3 and 2 (each within the scatter of the next); then compound 1.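

In this assay, ethyl((pyridin-4-yl)methyl)amino in place of 5-chloro-2,3-dihydro-1H-indol-1-yl on a thiocarbonyl carbon gives a 1.4-fold lower number from compound 2 to compound 3 (0.14 log units; within the scatter). The position therefore accepts this exchange of groups with no change beyond the scatter, and neither the chlorine nor the five-membered non-aromatic ring is required to hold the number at this level. Nothing available explains this result.

Open, as far as these compounds go, is which part of the entering group matters. A phenyl in place of the pyridin-4-yl, or a propyl in place of the ethyl, would separate the two parts.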